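The compounds below may be only part of what the source reports. "The series", "measured", "known", "first", "only" and "open" are said of these compounds alone.

The compounds measured so far in a functional assay on NT2 cells (Homo sapiens) for inhibition; on this read-out lower numbers stand for stronger inhibition and higher numbers for weaker inhibition:
Compound 1, `CCC(C(=O)N[C@@H](CC(=O)O)C(=O)CSCc1ccccc1)n1ccnc(NCc2cc(C)no2)c1=O`, gives 6.41 nM.
Compound 2, `CCC(C(=O)N[C@@H](CC(=O)O)C(=O)CNCN1CCC(Cc2ccccc2)CC1)n1ccnc(NCc2nonc2C)c1=O`, gives 1.62 nM.

Compound 1 stands with the higher of the two numbers; compound 2 sits at a lower number, and the gap between them lies beyond the usual scatter. Among the measured compounds shown here, compound 1 and compound 2 differ in more than one place, so the two values show only that compound 2 is the stronger inhibitor of the pair; no single change can be read from them.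

Compound 3, `CCC(C(=O)N[C@@H](CC(=O)O)C(=O)CSCc1ccccc1)n1ccnc(NCCCOC)c1=O`, has not yet been measured. It differs from compound 1 in one place: 2-methoxyethyl in place of 3-methyl-1,2-oxazol-5-yl on a saturated chain carbon bound to a nitrogen on an aromatic ring. A five-membered aromatic ring with two hetero atoms gives way to an open chain with one hydrogen-bond acceptor, on a saturated chain carbon bound to a nitrogen on an aromatic ring. For the measured compounds named here, with no step between measured compounds to draw on, the direction rests on the change alone. A modest weakening is expected, so the step from compound 1 to compound 3 in this assay is estimated as a 2.3-fold higher number from compound 1 to compound 3 (0.37 log units; beyond the scatter), somewhat beyond the scatter. Compound 3 is therefore expected to give 15 nM in this assay, within a range from 5 nM to 50 nM.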

Compound 3, half-maximal inhibitory concentration: > 10 nM
Compound 3 gave a limit, no number (the forecaster's own chance of this, stated with the estimate: 5%); the middle value does not contradict the limit.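

In this assay compound 3 gives > 10 nM, which is a limit of the assay and not a number. Among the compounds shown here, it supplies the first step that can be read at this position, on a saturated chain carbon bound to a nitrogen on an aromatic ring, since the earlier pair differed in more than one place: 2-methoxyethyl in place of 3-methyl-1,2-oxazol-5-yl gives an at least 1.5-fold higher number from compound 1 to compound 3 (0.19 log units; that floor lies within the scatter). The step points towards weaker inhibition, yet it is only a floor, so the open chain is not shown to cost more than the scatter, and the step's true size stays unknown because compound 3 gave a limit: the limit of > 10 nM in this assay, at which 1 of the 3 values shown sits.

From the compounds shown here alone, how far the true value of compound 3 lies from its limit remains open, and so does whether the step follows from losing the ring or from the chain that replaces it. Also open, going by these compounds, is how a plain phenyl group, or a chain ending in an amine or a carboxylic acid, would read at this place in this assay.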